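The compounds below may be only part of what the source reports. "The series", "measured", "known", "first", "only" and "open" are said of these compounds alone.

Measured so far in an ADME assay on HFF cells (Homo sapiens) for cytotoxicity, read by MTT assay, with a stated time of 72 h; a higher number here means a weaker inhibitor, a lower number a stronger inhibitor:
compound 1, `CC(C)(C)c1cn(C[C@H](O)[C@H]2OC(=O)C(OCc3ccccc3)=C2OCc2ccccc2)nn1`, gives 13300 nM.
compound 2, `O=C1O[C@H]([C@@H](O)Cn2cc(C3CC3)nn2)C(OCc2ccccc2)=C1OCc1ccccc1`, gives 24300 nM.
compound 3, `O=C1O[C@H]([C@@H](O)Cn2cc(-c3cc(F)cc(F)c3)nn2)C(OCc2ccccc2)=C1OCc1ccccc1`, gives > 100000 nM, which is a limit of the assay rather than a number.

Among these three values, compound 3 therefore has only a limit; it sits at the limit of > 100000 nM in this assay, at which 1 of the 3 values shown sits. Both measured steps that lead to it point the same way: an at least 7.5-fold higher number from compound 1 to compound 3 (0.87 log units; beyond the scatter) and an at least 4.1-fold higher number from compound 2 to compound 3 (0.61 log units; beyond the scatter), each beyond the scatter, whereas a 1.8-fold higher number from compound 1 to compound 2 (0.26 log units; within the scatter) stays within it. How far beyond the limit compound 3 really lies cannot be read from these numbers.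

Compound 4, `Cc1ccc(S(=O)(=O)NCc2cn(C[C@H](O)[C@H]3OC(=O)C(OCc4ccccc4)=C3OCc3ccccc3)nn2)cc1`, has not yet been measured in this assay. It differs from compound 3 by (((4-methylphenyl)sulfonyl)amino)methyl in place of 3,5-difluorophenyl on an aromatic carbon. Within the data shown here, none of the measured steps involves this entering group, so they bear on the step only by showing that compound 3 already sits at the limit of the assay. The two steps into compound 3 show that exchanging the group at this position can move the number beyond the scatter, but in which direction a further exchange would move it is not known. Compound 4 is therefore expected to give 80000 nM in this assay, between 25000 nM and 250000 nM, with a fair chance that only a limit is reported again. The step of an at least 1.2-fold lower number from compound 3 to compound 4 (0.09 log units; that floor lies within the scatter) is accordingly estimated to be small.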

Compound 4, half-maximal inhibitory concentration: 50 nM
Estimate against measurement, compound 4: 1600-fold (3.20 log units) above, and the stated range ends above it.
By their numbers in this assay, from the lowest: compound 4; then compounds 1 and 2 (each within the scatter of the next). At a limit, above all of these: compound 3.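

Until now, exchanges on the aromatic carbon of the five-membered aromatic ring with 3 nitrogen had left the number in this assay within the scatter or raised it, but this position can also lower it sharply: the sulfonyl-bearing group gives a 490-fold lower number from compound 2 to compound 4 (2.69 log units; beyond the scatter) and a 270-fold lower number from compound 1 to compound 4 (2.42 log units; beyond the scatter), both large steps and both read from real numbers at each end. For compound 3 the value is a limit of the assay and not a number, so an at least 2000-fold lower number from compound 3 to compound 4 (3.30 log units; beyond the scatter) gives only a floor for the size of that step: the limit of > 100000 nM in this assay, at which 1 of the 4 values shown sits. Among these compounds, the change swaps 3,5-difluorophenyl, with no hydrogen-bond donors or acceptors, for (((4-methylphenyl)sulfonyl)amino)methyl, which has both, and it is the first group here to bring the number far below those of compound 1 and compound 2.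

The compounds shown leave open which part of the entering group goes with this low number: the sulfonyl, the amino hydrogen or the 4-methylphenyl ring. As far as these compounds go, whether a plain aminomethyl, a carboxamide or a longer chain in place of the methyl would keep the number as low also remains open.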